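Compound 2 to compound 4: one more 4-methylphenyl

The compounds below may be only part of what the source reports. "The series", "measured", "known", "first", "only" and "open" are said of these compounds alone.

Measured in an ADME assay on TZM cells (Homo sapiens) for cytotoxicity, with a stated time of 48 h; a lower number here means that less compound is tolerated, a higher number that more compound is tolerated:
- Compound 1 `Cc1ccc(Nc2nc(NCC3CCCO3)nc(NCC3CCCO3)n2)cc1`: > 50000 nM
- Compound 2 `Cc1ccc(Nc2nc(N)nc(Nc3ccc(C)cc3)n2)cc1`: 57000 nM
- Compound 3 `Cc1ccc(Nc2nc(O)nc(Nc3ccc(C)cc3)n2)cc1`: > 12500 nM

Going by the values given here, compound 2 gives 57000 nM, the only true number in the set. Compound 1 gives > 50000 nM, which is a limit of the assay and not a number. Compound 3 gives > 12500 nM, which is likewise a limit. Compound 2 therefore cannot be ranked against either of the other two.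

The next compound to be measured is compound 4 (`Cc1ccc(Nc2nc(Nc3ccc(C)cc3)nc(Nc3ccc(C)cc3)n2)cc1`). The change is 4-methylphenyl in place of hydrogen on a nitrogen on an aromatic ring, which turns the amino group of compound 2 into (4-methylphenyl)amino. Among the compounds with values here, the only measured step at that amino group is a step that the limit leaves unreadable from compound 2 to compound 3, and it offers no size to carry over. It is also a different replacement, hydroxy in place of amino. The expectation in this assay therefore rests on compound 2 with its 57000 nM as the starting point, and no direction is supported by a measured step. The estimated move is a 1.6-fold lower number from compound 2 to compound 4 (0.21 log units; within the scatter), so no step beyond the usual scatter is expected, though the uncertainty is wide. A limit rather than a number would not be a surprise in this series. For compound 4 the expected value is 35000 nM, with an estimated range from 10000 nM to 100000 nM.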

Compound 4, half-maximal cytotoxic concentration: > 50000 nM
Compound 4: a limit, no number (the forecaster's own chance of this, stated with the estimate: 55%); middle value at least 1.4-fold (0.15 log units) from the limit.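

In this assay compound 4 gives > 50000 nM, which is a limit of the assay and not a number. Going by these compounds alone, no step can therefore be read from compound 2 or compound 3 to compound 4. The compounds shown leave open whether 4-methylphenyl in place of hydrogen on the amino nitrogen of compound 2 changes the tolerated concentration at all, and by how much.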